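A few compounds are considered here, and "the series" means these few. Any claim that something is new, unique, unknown or untested is made for them only; others in the source may bear on it.

Measured so far:
- compound 1, `COc1ccc2c(c1)OC(OC)(c1ccccc1)C(O)(O)C2=O`: 20 ug/mL
- compound 2, `COc1ccc(-c2coc3cc(OC)c(OC)c(OC)c3c2=O)cc1`: 34 ug/mL

Both numbers come from a functional assay on KB cells (Homo sapiens) for cytotoxicity; a lower number here means that less compound is needed, a higher number that more compound is needed for the effect. Compound 1 holds the lower of the two values, but the gap to compound 2 lies within the usual scatter of this assay, so the two cannot be ordered against each other on these data alone, and neither can be called the more or less active of the pair. Within the data shown here, no pair of measured compounds differs in a single place, so no measured step is available to anchor an expectation.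

Compound 3, `COc1ccc(C2(OC)Oc3cc(OC)ccc3C(=O)C2(O)O)cc1`, remains to be measured. It differs from compound 1 in one place: methoxy in place of hydrogen on an aromatic carbon. The group that enters sits on an aromatic carbon of a six-membered aromatic ring of carbon only, on the phenyl that becomes a 4-methoxyphenyl.

Among the measured compounds shown here, with no comparable step on record, the expected step is small: no change beyond the scatter, in either direction, is anticipated, so the estimate for compound 3 is set near the value of compound 1, with a wide range. Compound 3 is expected to give 18 ug/mL in this assay, between 8 ug/mL and 45 ug/mL. This corresponds to an expected step of a 1.1-fold lower number from compound 1 to compound 3 (0.05 log units; within the scatter).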

Compound 3, concentration for half-maximal effect: 2.8 ug/mL
For compound 3 the middle estimate is 6.4-fold (0.81 log units) above the measured one, and the stated range ends above it.
By their numbers in this assay, from the lowest: compound 3; then compounds 1 and 2 (each within the scatter of the next).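

Among these compounds, the change from phenyl to 4-methoxyphenyl in this assay gives a 7.1-fold lower number from compound 1 to compound 3 (0.85 log units; beyond the scatter) and is the first step to lie beyond the scatter, which shows that the number responds to substitution at this aromatic carbon, para to a large group, on the core of compound 1. The finding rests on one matched pair and one entering group, so it supports a statement about methoxy in place of hydrogen at this place and no wider trend across substituents or across the series. Nothing on record bears on the reason for this step.

The compounds shown leave open whether the lower number is specific to methoxy, since a hydroxyl, a fluorine atom, a dimethylamino group or a longer chain such as ethoxy at the same place would each test how far the step depends on the entering group. They also leave open whether methoxy at another carbon of the same ring would give a step of similar size, and whether the step would recur on a different core.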